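The compounds below may be only part of what the source reports. "The series", "measured", "known", "first", "only" and "open" are said of these compounds alone.

Of the compounds shown here, three built on one shared core have been tested in a functional assay on PC-3 cells (Homo sapiens) for inhibition; on this read-out higher numbers stand for weaker inhibition and lower numbers for stronger inhibition. Compound 1 `Cc1c(C(=O)N/N=C\c2ccccc2F)oc2cccc(O)c12` gives a value that is a limit of the assay rather than a number, >= 40000 nM. Compound 2 `Cc1c(C(=O)N/N=C\c2ccccc2C(F)(F)F)oc2cccc(O)c12` gives 26200 nM. Compound 3 `Cc1c(C(=O)N/N=C\c2c(O)cccc2F)oc2cccc(O)c12` gives 8050 nM, the lower of the two numbers, with compound 2 behind it by a gap beyond the scatter.

Two steps have been measured, both starting from compound 1. The step of an at least 1.5-fold lower number from compound 1 to compound 2 (0.18 log units; that floor lies within the scatter) is only a floor, since compound 1 sits at the limit of >= 40000 nM in this assay, at which 1 of the 3 values shown sits. The step of an at least 4.9-fold lower number from compound 1 to compound 3 (0.69 log units; beyond the scatter) is the larger of the two and clears the scatter.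

Compound 4 `Cc1c(C(=O)N/N=C\c2c(O)cccc2Cl)oc2cccc(O)c12` differs from compound 3 in one place: chloro in place of fluoro on an aromatic carbon. Among the compounds with values here, no measured step swaps one halogen for another on this ring, so the expectation leans on the nearest case, the step from fluoro to a bulkier trifluoromethyl, which reached only a floor that lies within the scatter. A halogen swap of similar kind is therefore expected to move the number little, and the step from compound 3 to compound 4 is estimated as a 1.2-fold lower number from compound 3 to compound 4 (0.09 log units; within the scatter). Compound 4 is accordingly expected to give 6500 nM in this assay, within a range from 2500 nM to 17000 nM.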

Compound 4, half-maximal inhibitory concentration: 18700 nM
Beside the measured number, compound 4's estimate is 2.9-fold (0.46 log units) below it, outside the stated range (above it).
By their numbers in this assay, from the lowest: compound 3; then compounds 4 and 2 (each within the scatter of the next). At a limit, above all of these: compound 1.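

Within the data shown here, at this position on the 2-fluoro-6-hydroxyphenyl group, two halogens can now be compared directly for the first time, and the choice matters: in this assay, putting chloro in place of fluoro gives a 2.3-fold higher number from compound 3 to compound 4 (0.37 log units; beyond the scatter). Since a higher number means weaker inhibition here, fluoro is the better of these two halogens when the hydroxy group is present, although the numbers alone do not say what property of the halogen lies behind the difference. Even so, the change from 2-fluorophenyl to 2-chloro-6-hydroxyphenyl gives an at least 2.1-fold lower number from compound 1 to compound 4 (0.33 log units; beyond the scatter), which changes two places on the ring at once and is only a floor, because the starting value is a limit of the assay: the limit of >= 40000 nM in this assay, at which 1 of the 4 values shown sits.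

The compounds shown leave open whether fluoro and chloro would differ in the same way on a ring that lacks the hydroxy group, so the gain from the hydroxy group cannot yet be separated for chloro. They also leave open how a bromo, methyl, methoxy or amino group would behave at this same position, which would show whether the trend extends beyond these two halogens.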